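The compounds below may be only part of what the source reports. "The series", "measured", "known", "first", "only" and "open" are said of these compounds alone.

In a functional assay on MX1 cells (Homo sapiens) for antiproliferative activity, with a stated time of 72 h (on this read-out lower numbers stand for an effect already at smaller amounts and higher numbers for an effect only at larger amounts of compound), compound 2 `CCS(=O)(=O)Nc1ccc(Oc2ccc(C#N)cc2)c(-c2cn(C)c(=O)c3[nH]ccc23)c1` gives 17 nM and compound 3 `Cn1cc(-c2cc(NS(C)(=O)=O)ccc2Oc2ccc(F)cc2F)c2cc[nH]c2c1=O` gives 29 nM and these two numbers lie within the usual scatter of each other. Compound 1 `Cn1cc(-c2ccccc2Oc2ccccc2)cc(N)c1=O` is reported only as a limit of > 5000 nM in this series. Compound 4 `CCS(=O)(=O)Nc1ccc(OC2CCC(N(C)C)CC2)c(-c2cn(C)c(=O)c3[nH]ccc23)c1` has not yet been measured. It differs from compound 2 in one place, on an oxygen on an aromatic ring, where 4-(dimethylamino)cyclohexyl stands in place of 4-cyanophenyl 4-(dimethylamino)cyclohexyl in place of 4-cyanophenyl on an oxygen on an aromatic ring and the aromatic ring leaves. Among the measured compounds shown here, no measured pair shows such a change, so the guide is only compound 2 at 17 nM and the expectation is cautious. The expected step of a 7.1-fold higher number from compound 2 to compound 4 (0.85 log units; beyond the scatter) runs towards a higher number in this assay and beyond the scatter. Compound 4 is estimated at 120 nM with an expected range from 25 nM to 600 nM in this read-out.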

Compound 4, half-maximal effective concentration: 86 nM
Estimate against measurement, compound 4: 1.4-fold (0.14 log units) above, and the stated range covers the measured number.
By their numbers in this assay, from the lowest: compounds 2 and 3 (each within the scatter of the next); then compound 4. At a limit, above all of these: compound 1.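

In this assay the place on an oxygen on an aromatic ring also accepts a non-aromatic ring: 4-(dimethylamino)cyclohexyl in place of 4-cyanophenyl still leaves compound 4 with a measurable effect, at the cost of a modest step (a 5.1-fold higher number from compound 2 to compound 4 (0.70 log units; beyond the scatter)). Among the compounds shown here, the earlier compounds carried only aromatic rings at this place, so this is the first reading of a non-aromatic one there. Nothing given here accounts for the size of this step. Going by these compounds, whether the step follows from the loss of the aromatic ring or from the dimethylamino group stays open. A plain cyclohexyl or an open-chain amine on the same oxygen would separate the two.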